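A few compounds are considered here, and "the series" means these few. Any claim that something is new, unique, unknown or untested is made for them only; others in the source may bear on it.

In an ADME assay on HEK-293T cells (Homo sapiens) for cytotoxicity, read by CCK-8 assay, with a stated time of 48 h (on this read-out lower numbers stand for stronger inhibition and higher numbers for weaker inhibition), compound 3 (`COc1ccc(NC(=S)NCCNS(=O)(=O)c2sccc2-c2ccc(C)cc2Oc2ccc(O)c(O)c2)cc1`) gives > 20000 nM as a limit of the assay and not a number. Compound 1 (`COc1ccc(NC(=O)NCCNS(=O)(=O)c2sccc2-c2ccc(C)cc2Oc2ccc(O)c(O)c2)cc1`) gives > 20000 nM as a limit too. That leaves compound 3 at the limit of > 20000 nM in this assay, at which 2 of the 3 values shown sit, with no exact position of its own. Compound 2 (`O=S(=O)(NCCNC(=S)Nc1cc(C(F)(F)F)cc(C(F)(F)F)c1)c1ccc(-c2ccccc2OCc2ccccc2)s1`) gives a true number of 8500 nM in this assay and is the only one of the three to do so.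

Compound 4 (`Cc1ccc(-c2ccsc2S(=O)(=O)NCCNC(=S)Nc2ccc([N+](=O)[O-])cc2)c(Oc2ccc(O)c(O)c2)c1`) differs from compound 3 in one place, with nitro in place of methoxy on an aromatic carbon, para to a large group (nitro in place of methoxy on an aromatic carbon). For the measured compounds named here, the only measured step between two close relatives is a step that the two limits leave unreadable from compound 1 to compound 3 and it involves a different change, so it offers no size to carry over. Going by the values given here, no measured step covers this swap of methoxy for nitro.

The expectation therefore rests on the values alone. Compound 3 at > 20000 nM suggests that compound 4 will stay weak, while compound 2 at 8500 nM shows that a true number can appear in this series. A small move toward stronger inhibition is expected, estimated as an at least 1.1-fold lower number from compound 3 to compound 4 (0.07 log units; that floor lies within the scatter) in size. The estimated value for compound 4 is 17000 nM with an expected range from 7000 nM to 30000 nM and the assay may well report only a limit again.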

Compound 4, half-maximal inhibitory concentration: 8200 nM
Compound 4: middle estimate off by 2.1-fold (0.32 log units), on the high side; the range from low to high includes it.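

In this assay, the swap from 4-methoxyphenyl to 4-nitrophenyl is the first change among these compounds to give a step with a readable lower bound, an at least 2.4-fold lower number from compound 3 to compound 4 (0.38 log units; beyond the scatter), so a single change at this position can bring the read-out from a limit down to a true number. The larger change from the other limit compound points the same way, with an at least 2.4-fold lower number from compound 1 to compound 4 (0.38 log units; beyond the scatter), while the earlier step between the two limit compounds cannot be read. Both readable steps give only a minimum size, as each starts from a compound whose result is a limit of the assay and not a number: the limit of > 20000 nM in this assay, at which 2 of the 4 values shown sit.

On these data alone, the true values of compound 1 and compound 3 remain unknown, so the full size of both steps stays open, and with it how much of the change in compound 4 comes from nitro taking the place of methoxy. Also open, as far as these compounds go, is how other groups on this aromatic carbon, such as an amine, a nitrile or a carboxylic acid, would read in this assay, and whether the same swap would give a similar step in the urea form of compound 1.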